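This account rests on a few compounds, and the source may have more. Where it says the series, first, only, none or still open, it means among the compounds named here.

Notes on the series. Compound 1 `C#CCSc1nc(Nc2ccccc2)c2ccncc2n1` and compound 2 `C#CCSc1nc(N2CCN(C)CC2)c2ccncc2n1` share a core. In a functional assay on PC-3 cells (Homo sapiens) for inhibition, read by MTT assay, with a stated time of 72 h (on this read-out higher numbers stand for weaker inhibition and lower numbers for stronger inhibition), compound 1 gives only the assay limit > 80000 nM. Compound 2 likewise gives only the assay limit > 80000 nM in this assay. The step that the two limits leave unreadable from compound 1 to compound 2 therefore cannot be read, as both values sit at the limit of > 80000 nM in this assay, at which 2 of the 2 values shown sit. Compound 3 `C#CCSc1nc(N2CCN(C(=O)OC(C)(C)C)CC2)c2ccncc2n1` carries tert-butoxycarbonyl in place of methyl on an amine nitrogen in a ring. For the measured compounds named here, no measured step bears on this change, and compound 2 itself sits at the limit, so no direction can be drawn. Compound 3 is expected to stand at about 100000 nM (between 30000 nM and 300000 nM), most likely again as a limit. The step that the limit leaves unreadable from compound 2 to compound 3 is the estimate implied.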

Compound 3, half-maximal inhibitory concentration: 47500 nM
Compound 3: the middle estimate sits 2.1-fold (0.32 log units) above what was measured; the range from low to high includes it.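

For the compounds shown here, on the amine nitrogen in the ring, tert-butoxycarbonyl in place of methyl gives the first value in this assay that is a number and not a limit, with an at least 1.6-fold lower number from compound 2 to compound 3 (0.22 log units; that floor lies within the scatter). On these data alone, the true size of this step stays unknown, and its floor alone shows no change beyond the usual scatter. The other values shown remain limits: the limit of > 80000 nM in this assay, at which 2 of the 3 values shown sit.

Open, as far as these compounds go, is whether an acetyl or a benzyl group on the same nitrogen would also give a number and not a limit. Also open, from the compounds shown here alone, is whether a value of this size depends on the carbonyl or on the tert-butyl part of the group.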